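Nitro sulfonyl benzamide series: a tetrahydroisoquinoline amide

This account rests on a few compounds, and the source may have more. Where it says the series, first, only, none or still open, it means among the compounds named here.

Measured so far in an assay on isolated protein for inhibition of thyroid hormone receptor alpha (Homo sapiens), read by fluorescence polarization; on this read-out lower numbers stand for stronger inhibition and higher numbers for weaker inhibition:
compound 1 `CCCN(C(=O)CN(C)C(=O)c1ccc(S(C)(=O)=O)c([N+](=O)[O-])c1)c1ccccc1`, compound 1 gives > 60000 nM
compound 2 `CS(=O)(=O)c1ccc(C(=O)N2CCC(C(=O)N3CCC(c4ccccc4)CC3)CC2)cc1[N+](=O)[O-]`, compound 2 gives > 60000 nM
compound 3 `CS(=O)(=O)c1ccc(C(=O)NCC(=O)N2CCN(c3ccccc3F)CC2)cc1[N+](=O)[O-]`, compound 3 gives > 60000 nM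

Each of these three values is a limit of this assay, not a number. Compound 1 thus stands nowhere apart from the others: as the limit of > 60000 nM in this assay, at which 3 of the 3 values shown sit, records, every value shown sits at that limit, and nothing separates the three. For the measured compounds named here, no two measured compounds differ in a single place, so no step within the set has been measured.

Compound 4 `CN(CC(=O)N1CCc2ccccc2C1)C(=O)c1ccc(S(C)(=O)=O)c([N+](=O)[O-])c1` is the unmeasured member. It differs from compound 1 in one place: 1,2,3,4-tetrahydroisoquinolin-2-yl in place of phenyl(propyl)amino on a carbonyl carbon. The shared core of compound 1, with its methylsulfonyl, nitro, tertiary amide and glycine linker, is kept unchanged.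

Going by the values given here, with no measured step to draw on, the size of the step cannot be taken from the data. The expected step is a number no higher from compound 1 to compound 4 (the limit leaves the size open), none beyond the scatter, because the starting point of compound 1 is itself the limit > 60000 nM. Compound 4 is estimated at 60000 nM, with a range from 20000 nM to 200000 nM, and most likely this assay will again report only a limit for compound 4.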

Compound 4, half-maximal inhibitory concentration: > 60000 nM
Compound 4: only a limit was reported; the forecaster's own chance of this, stated with the estimate: 85%; the middle value lies on the limit itself.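

No step can be read from compound 1 to compound 4 in this assay, as both values are limits: the limit of > 60000 nM in this assay, at which 4 of the 4 values shown sit.

The compounds shown leave open whether any member of the series gives a number rather than a limit in this assay, and what 1,2,3,4-tetrahydroisoquinolin-2-yl in place of phenyl(propyl)amino does to the read-out.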